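A Methoxy Group Added to Compound 2

The source may hold more compounds than are shown below. What is called first, only, known or untested is meant among the compounds shown, and "the series" means these compounds.

In a functional assay on HCT-116 cells (Homo sapiens) for cytotoxicity, read by sulforhodamine B assay, with a stated time of 48 h (on this read-out higher numbers stand for weaker inhibition and lower numbers for stronger inhibition), compound 1 `O=C(Nc1n[nH]c2c1CN(C(=O)c1ccccc1)C2)c1ccc(F)cc1` gives 3190 nM as its half-maximal inhibitory concentration, and compound 2 `CCCCNC(=O)N1Cc2c(NC(=O)c3ccccc3)nn(C(=O)C3CC3)c2C1` gives 3470 nM on the same read-out. These two numbers lie within the usual scatter of each other, so compound 2 stands level with compound 1. Compound 3 `CCCCNC(=O)N1Cc2c(NC(=O)c3ccc(OC)cc3)nn(C(=O)C3CC3)c2C1` differs from compound 2 at one place, where the change is methoxy in place of hydrogen on an aromatic carbon and phenyl becomes 4-methoxyphenyl, with methoxy in place of hydrogen on an aromatic carbon. Among the compounds with values here, no measured step shows what this change does. Resting on compound 2 at 3470 nM as the closest measured relative, the expectation in this assay is no shift beyond the scatter, in either direction. The expected size is a 1.2-fold lower number from compound 2 to compound 3 (0.06 log units; within the scatter) in this estimate. For compound 3 the estimated value is 3000 nM with an expected range from 1300 nM to 7000 nM once measured.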

Compound 3, half-maximal inhibitory concentration: 65500 nM
For compound 3 the middle estimate is 22-fold (1.34 log units) below the measured one; the whole stated range lies below it.
By their numbers in this assay, from the lowest: compounds 1 and 2 (each within the scatter of the next); then compound 3.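

In this assay, methoxy in place of hydrogen on an aromatic carbon, para to a large group, gives a 19-fold higher number from compound 2 to compound 3 (1.28 log units; beyond the scatter) and so weakens inhibition well beyond the scatter. Within the data shown here, compounds 1 and 2 stood level and offered no step in one place, so this is the first sign that the benzoyl ring of compound 2 does not accept every substituent at this position without loss. Nothing at hand bears on why the added methoxy has this effect.

This single step cannot separate an effect of methoxy itself from one that any substituent here might bring. The compounds shown also leave open how a hydroxyl, an amine or a carboxylic acid would fare on this same aromatic carbon, and how methoxy would fare elsewhere on the ring.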